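The source may hold more compounds than are shown below. What is called first, only, known or untested is meant among the compounds shown, and "the series" means these compounds.

Values in a physicochemical assay for solubility, read by spectrophotometry, in phosphate buffer, measured as kinetic solubility, with a stated time of 18 h, at pH 7.4; a lower number here means a less soluble compound, a higher number a more soluble compound:
- Compound 1 `Cc1ccc(-c2nc3ccccc3s2)cc1NC(=O)c1cc([N+](=O)[O-])c(N2CCC(C(=O)O)CC2)cc1Cl`: 590 nM
- Compound 2 `COc1ccc(-c2nc3ccccc3s2)cc1NC(=O)c1cc([N+](=O)[O-])c(N2CCC(C(=O)O)CC2)cc1Cl`: 210 nM
- Compound 3 `COc1ccc(-c2nc3ccccc3s2)cc1NC(=O)c1cc([N+](=O)[O-])c(N2CCN(C)CC2)cc1Cl`: not yet measured

Compound 2 stands lowest of the two measured compounds. Compound 3 keeps its core but carries 4-methylpiperazin-1-yl in place of 4-carboxypiperidin-1-yl on an aromatic carbon. Among the compounds with values here, the only measured step, a 2.8-fold lower number from compound 1 to compound 2 (0.45 log units; beyond the scatter), is modest and concerns a different group, so no measured step tests this change directly. The expected move in this assay is a 3.3-fold higher number from compound 2 to compound 3 (0.52 log units; beyond the scatter), with weak support. Compound 3 is estimated at 700 nM, with an expected range of 120 nM to 4000 nM.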

Compound 3, solubility: 500 nM
The estimate for compound 3 lay 1.4-fold (0.15 log units) above the measured number, and the stated range covers the measured number.
By their numbers in this assay, from the lowest: compound 2; then compounds 3 and 1 (each within the scatter of the next).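

In this assay, the aromatic carbon ortho to the nitro group now has a measured change: 4-methylpiperazin-1-yl in place of 4-carboxypiperidin-1-yl gives a 2.4-fold higher number from compound 2 to compound 3 (0.38 log units; beyond the scatter). Within the data shown here, the earlier step concerned only methoxy in place of methyl elsewhere on the shared core, so this is the first reading at this position. No measurement is available that explains the step.

Still open, going by these compounds, is how morpholin-4-yl, or a piperidine carrying an amine in place of the carboxylic acid, would read at this position. Also open, on these data alone, is whether the step holds with methyl in place of methoxy.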